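This account rests on a few compounds, and the source may have more. Where it says the series, first, only, none or still open, it means among the compounds named here.

Measured so far in an assay on CHO cells for displacement of a labelled ligand from 5-hydroxytryptamine receptor 1B (Homo sapiens); a higher number here means a weaker inhibitor, a lower number a stronger inhibitor: compound 1 `c1c[nH]c(CN2CCN(CCCc3c[nH]c4ccc(-n5cnnc5)cc34)CC2)n1` at 36 nM; compound 2 `CC(=O)Nc1ccc(CN2CCN(CCCc3c[nH]c4ccc(-n5cnnc5)cc34)CC2)cc1` at 56 nM; compound 3 `CN(C)C(=O)C(c1ccccc1)N1CCN(CCCc2c[nH]c3ccc(-n4cnnc4)cc23)CC1` at 102 nM.

Compound 1 gives the lowest of the three numbers in this assay. Its nearest neighbour is compound 2, and the change there reads a 1.6-fold higher number from compound 1 to compound 2 (0.19 log units; within the scatter). Compound 3 stands further out, with its value set against that of compound 1 showing a gap beyond the scatter.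

Compound 4 `CN1CCN(CCCc2c[nH]c3ccc(-n4cnnc4)cc23)CC1` differs from compound 1 as follows: hydrogen in place of 1H-imidazol-2-yl on a saturated chain carbon bound to an amine nitrogen in a ring. Going by the values given here, the one step that bears on this, from compound 1 to compound 2, exchanged the same group for another and stayed within the scatter. Among the compounds with values here, no measured step removes the group outright, so the expectation rests on that single comparison and on the wider spread seen with compound 3.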

Compound 4, half-maximal inhibitory concentration: 309 nM
The estimate for compound 4 lay 3.9-fold (0.59 log units) below the measured number; measured number outside the range, above it.
By their numbers in this assay, from the lowest: compounds 1, 2 and 3 (each within the scatter of the next, the first and the last beyond it); then compound 4.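

In this assay, replacing either group with hydrogen matters far more than exchanging one group for the other: removing 1H-imidazol-2-yl gives an 8.6-fold higher number from compound 1 to compound 4 (0.93 log units; beyond the scatter) and removing 4-acetamidophenyl gives a 5.5-fold higher number from compound 2 to compound 4 (0.74 log units; beyond the scatter) at the same place. A substituent on this saturated chain carbon bound to an amine nitrogen in a ring is therefore associated with the lower numbers in these pairs, though the two groups themselves remain within the scatter of each other. No evidence is available to explain this difference.

The compounds shown leave open whether a methyl, a primary amine or a carboxylic acid on that carbon would give numbers like those of compound 1. They also leave open whether a ring is needed there at all.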